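The source may hold more compounds than are shown below. What is called first, only, known or untested is meant among the compounds shown, and "the series" means these compounds.

Compound 1 `C=CCOc1cc(OC)c(C(=O)/C=C/Cc2ccccc2)c(OCC=C)c1`: 14800 nM
Compound 2 `COc1cccc(/C=C/C(=O)c2c(O)cc(O)cc2OC)c1`: 17600 nM

In a toxicity assay on cells (Macrophage, Mus musculus, strain BALB/c) for cytotoxicity, read by MTT assay (a lower number here means a stronger inhibitor, a higher number a weaker inhibitor), compound 1 gives 14800 nM, the lowest of the two numbers, but its nearest neighbour, compound 2, gives 17600 nM, and that gap is within the scatter, so the two cannot be told apart.

Compound 3 `C=CCOc1cc(OC)c(C(=O)/C=C/c2ccc(OC)cc2)c(OCC=C)c1` has not yet been measured. It differs from compound 1 in one place: 4-methoxyphenyl in place of benzyl on a double-bonded chain carbon bound to a double-bonded chain carbon. Among the compounds with values here, no measured pair shows what this exchange does, so nothing known here fixes the direction of the step, and the one other measured compound, compound 2, sits where compound 1 sits.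

With that in mind, compound 3 is expected to give about 12000 nM in this assay, within a range of 4000 nM to 40000 nM. The expected step of a 1.2-fold lower number from compound 1 to compound 3 (0.09 log units; within the scatter) is none beyond the scatter, in either direction.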

Compound 3, half-maximal inhibitory concentration: 18700 nM
Estimate against measurement, compound 3: 1.6-fold (0.19 log units) below; the range from low to high includes it.
By their numbers in this assay, from the lowest: compounds 1, 2 and 3 (each within the scatter of the next).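

In this assay, putting 4-methoxyphenyl in place of benzyl on a double-bonded chain carbon bound to a double-bonded chain carbon gives a 1.3-fold higher number from compound 1 to compound 3 (0.10 log units; within the scatter). Within the data shown here, this is the only measured pair for this place, and it shows that this one exchange, which brings in a hydrogen-bond acceptor that benzyl does not have, leaves the two compounds impossible to tell apart in this cell test. No measurement shown here bears on why the two numbers lie so close.

The compounds shown leave open whether a quite different group at this place, such as an amine or a carboxylic acid, would give a step beyond the scatter. They also leave open what a plain phenyl would give here, which would separate the loss of benzyl from the arrival of the methoxy group.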